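Swapping the aryl group on a thiazole acetic acid

The source may report more compounds than this note shows. Statements on the series, on what has been measured and on what is new or still open speak of the compounds shown alone.

Compound 3 `NS(=O)(=O)c1cccc(-c2nc(C(c3ccc(F)cc3)c3ccc(F)cc3)sc2CC(=O)O)c1`: 140 nM
Compound 1 `O=C(O)Cc1sc(C(c2ccccc2)c2ccccn2)nc1-c1ccc(Cl)cc1`: 810 nM
Compound 2 `COc1ccc(OC)c(-c2nc(C(c3ccccc3)c3ccccc3)sc2CC(=O)O)c1`: > 105 nM

In an in vitro assay on HEK385-7 cells for displacement of a labelled ligand from prostaglandin D2 receptor 2 (Homo sapiens) (on this read-out higher numbers stand for weaker inhibition and lower numbers for stronger inhibition), compound 3 gives 140 nM, the lowest of the two numbers shown. Compound 1, which carries a pyridinyl group at the shared position, gives 810 nM in this assay, a step that lies beyond the usual scatter. For compound 2 this assay reports only a limit, > 105 nM, and no number.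

Compound 4 `Cc1cc(-c2nc(C(c3ccc(F)cc3)c3ccc(F)cc3)sc2CC(=O)O)ccn1` has not yet been measured in this assay. Its structure follows from compound 3 by one change: 2-methylpyridin-4-yl in place of 3-sulfamoylphenyl on an aromatic carbon. The group that leaves carries a hydrogen-bond donor; the group that enters has none. Within the data shown here, no measured pair shows this same change, so the direction of the step is uncertain. The expected outcome is a move toward a weaker result, an estimated step of a 2.9-fold higher number from compound 3 to compound 4 (0.46 log units; beyond the scatter) in this assay. Compound 4 is therefore expected to give about 400 nM, within a range from 120 nM to 1500 nM.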

Compound 4, half-maximal inhibitory concentration: 3.1 nM
The estimate for compound 4 lay 130-fold (2.11 log units) above the measured number; measured number outside the range, below it.
By their numbers in this assay, from the lowest: compound 4; then compound 3; then compound 1.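

In this assay, among these compounds, the group at this position of the shared core proves to have a strong hold on the result: 2-methylpyridin-4-yl in place of 3-sulfamoylphenyl gives a 45-fold lower number from compound 3 to compound 4 (1.65 log units; beyond the scatter) and is the first single change that can be read here. The hydrogen-bond donor of the leaving group is therefore not required for a low number in this pair, since the entering group has none and is also the smaller of the two. Compound 1 and compound 2 differ from compound 3 in more than one place, so neither could show this.

Nothing shown here explains why the step is so large. From the compounds shown here alone, it also stays open whether the ring nitrogen or the methyl matters more, which a plain pyridin-4-yl group or a methylphenyl group at the same position could separate.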